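A few compounds are considered here, and "the series" means these few. Any claim that something is new, unique, unknown or untested is made for them only; others in the source may bear on it.

In a functional assay on PC-3 cells (Homo sapiens) for cytotoxicity, read by MTT assay, with a stated time of 72 h (a higher number here means a weaker inhibitor, a lower number a stronger inhibitor), three related compounds have been measured so far. Compound 1 `COc1ccc(CCCOC(=O)CCc2ccc(O)cc2)cc1` gives 283000 nM, compound 2 `COc1cc(/C=C/COC(=O)/C=C/c2cc(OC)c(OC)c(OC)c2)cc(OC)c1OC` gives 189000 nM, and compound 3 `O=C(CCc1ccc(O)c(O)c1)OCCCc1ccccc1` gives 189000 nM. Compound 3 is therefore level with compound 2, and all three values lie within the usual scatter of repeated measurements, so none can be called stronger. Compound 4 `O=C(CCc1ccc(O)cc1)OCCCc1ccccc1` differs from compound 3 in one place: hydrogen in place of hydroxy on an aromatic carbon, with hydrogen in place of hydroxy on an aromatic carbon, ortho to a hydroxy group. For the measured compounds named here, no measured pair shows this change. In this assay, the expected outcome is a slightly higher number, not beyond the scatter, and the estimated step is a 1.3-fold higher number from compound 3 to compound 4 (0.12 log units; within the scatter). The estimated value for compound 4 is 250000 nM, with an expected range from 120000 nM to 500000 nM.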

Compound 4, half-maximal inhibitory concentration: 322000 nM
Beside the measured number, compound 4's estimate is 1.3-fold (0.11 log units) below it; the measured number falls inside the stated range.
By their numbers in this assay, from the lowest: compounds 2, 3, 1 and 4 (each within the scatter of the next).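

In this assay, hydrogen in place of hydroxy on an aromatic carbon, ortho to a hydroxy group, gives a 1.7-fold higher number from compound 3 to compound 4 (0.23 log units; within the scatter) and so shows no effect of this hydroxy that stands clear of the scatter. Hydrogen in place of methoxy on an aromatic carbon gives a 1.1-fold higher number from compound 1 to compound 4 (0.06 log units; within the scatter) and likewise stands clear of nothing. No measurement here helps to explain why these numbers lie so close. Going by these compounds, whether an amine or a carboxylic acid at this position would move the number beyond the scatter stays open. So does the effect of a longer chain in the shared core.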